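Methyl for Methoxy on the Anilide Ring

The compounds below may be only part of what the source reports. "The series", "measured", "known", "first", "only" and "open" are said of these compounds alone.

The series shares one core, seen in compound 1 `O=C1NCCN1c1ccc(S(=O)(=O)Nc2cccc(Br)c2)cc1`, which in a functional assay on DU-145 cells (Homo sapiens) for antiproliferative activity, read by sulforhodamine B assay, with a stated time of 48 h (on this read-out lower numbers stand for stronger inhibition and higher numbers for weaker inhibition), gives 340 nM. Compound 2 `COc1cc(NS(=O)(=O)c2ccc(N3CCNC3=O)cc2)cc(OC)c1OC` gives 51 nM in this assay, and compound 3 `COc1cccc(NS(=O)(=O)c2ccc(N3CCNC3=O)cc2)c1` gives 650 nM. Among these three numbers compound 3 stands highest; its nearest neighbour is compound 1, and the two lie within the scatter of each other, while compound 2 lies beyond it at a lower number. The step of a 1.9-fold higher number from compound 1 to compound 3 (0.28 log units; within the scatter) shows that exchanging bromo for methoxy at this position left the number essentially unchanged.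

Compound 4 `Cc1cccc(NS(=O)(=O)c2ccc(N3CCNC3=O)cc2)c1` differs from compound 3 by methyl in place of methoxy on an aromatic carbon. Among the compounds with values here, no measured step replaces methoxy with methyl, so only the step from compound 1 to compound 3, which stayed within the scatter, bears on the change. Compound 4 is therefore expected to show a step of a 1.1-fold lower number from compound 3 to compound 4 (0.03 log units; within the scatter) in this assay, that is, no change beyond the scatter. The estimate for compound 4 is 600 nM, with a range from 250 nM to 1500 nM.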

Compound 4, half-maximal inhibitory concentration: 580 nM
Compound 4: middle estimate off by 1.0-fold (0.01 log units), on the high side; low and high end bracket the measured number.
By their numbers in this assay, from the lowest: compound 2; then compounds 1, 4 and 3 (each within the scatter of the next).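

With a 1.1-fold lower number from compound 3 to compound 4 (0.05 log units; within the scatter) and a 1.7-fold higher number from compound 1 to compound 4 (0.23 log units; within the scatter) in this assay, methyl joins methoxy and bromo as a third group at this place on the ring, and all three values lie within the scatter of one another. The change also removes the oxygen and the one hydrogen-bond acceptor counted for methoxy, and this leaves no step beyond the scatter, so the read-out does not separate these three groups meta to the large group. No measurement of any other kind is at hand to explain this result.

The compounds shown leave open whether a group of another kind at this place, such as an amine, a carboxylic acid or a longer chain, would also stay within the scatter. They also leave open whether moving methyl to another carbon of this ring would change the number.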